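Swapping a Dimethyl-Oxazole for a Bare Pyrazole

This account rests on a few compounds, and the source may have more. Where it says the series, first, only, none or still open, it means among the compounds named here.

Measured so far:
Compound 1, `Cc1cc(C)c(CN2CCc3c(C)cc(O[C@@H]4CCOC4)c(Cl)c3C2=O)c(=O)[nH]1`: 290 nM
Compound 2, `Cc1cc(C)c(CN2CCc3c(Cl)cc(-c4c(C)noc4C)c(Cl)c3C2=O)c(=O)[nH]1`: 15 nM
Compound 3, `Cc1cc(C)c(CN2CCc3c(Cl)cc(-c4c(C)n[nH]c4C)c(Cl)c3C2=O)c(=O)[nH]1`: 502 nM

The three compounds share one core and differ only in the group fixed to its aromatic carbon. In an assay on cells for inhibition of histone-lysine N-methyltransferase EZH2 (Homo sapiens), read by ELISA, with a stated time of 72 h (a higher number here means a weaker inhibitor, a lower number a stronger inhibitor), compound 2 gives 15 nM, the lowest number of the three, so it is the strongest inhibitor here, with compound 1 next and compound 3 furthest away. Compound 4, `Cc1cc(C)c(CN2CCc3c(Cl)cc(-c4cn[nH]c4)c(Cl)c3C2=O)c(=O)[nH]1`, has not been measured; it differs from compound 2 as follows: 1H-pyrazol-4-yl in place of 3,5-dimethyl-1,2-oxazol-4-yl on an aromatic carbon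

Within the data shown here, one measured step bears directly on this change. Replacing the same ring by a related five-membered ring gave a 33-fold higher number from compound 2 to compound 3 (1.52 log units; beyond the scatter). Compound 4 keeps the ring type of compound 3 but without its two methyl groups, so the data give no reason to expect the loss to be undone; a step of similar size in the same direction, toward a weaker inhibitor, is expected. On that basis compound 4 is expected to give about 600 nM in this assay, within 150 nM to 3000 nM, an expected step of a 40-fold higher number from compound 2 to compound 4 (1.60 log units; beyond the scatter).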

Compound 4, half-maximal inhibitory concentration: 1730 nM
For compound 4 the middle estimate is 2.9-fold (0.46 log units) below the measured one; low and high end bracket the measured number.
By their numbers in this assay, from the lowest: compound 2; then compounds 1 and 3 (each within the scatter of the next); then compound 4.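

Taking the two methyl groups off the pyrazole ring weakens inhibition further in this assay, with a 3.4-fold higher number from compound 3 to compound 4 (0.54 log units; beyond the scatter), so at this aromatic carbon the methyl groups count as well as the ring type. The full replacement of the 3,5-dimethyl-1,2-oxazol-4-yl group by 1H-pyrazol-4-yl gives a 120-fold higher number from compound 2 to compound 4 (2.06 log units; beyond the scatter), the largest step among these compounds. No measurement shown here explains why either change weakens inhibition.

Still open, from the compounds shown here alone, is whether a pyrazole ring with a single methyl group would fall between compound 3 and compound 4, and how a 1,2-oxazole ring without methyl groups would compare with compound 2. Also open, going by these compounds, is what ethyl groups in place of the methyl groups, or a phenyl ring or an amine at this aromatic carbon, would do.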